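The source may report more compounds than this note shows. Statements on the series, on what has been measured and on what is new or still open speak of the compounds shown alone.

Of the compounds shown here, three of one series have been measured in a functional assay for inhibition of sodium/hydrogen exchanger (Oryctolagus cuniculus); on this read-out higher numbers stand for weaker inhibition and lower numbers for stronger inhibition. Compound 1 `CS(=O)(=O)c1cc(C(=O)N=C(N)N)c(Cl)cc1Cl` gives 140 nM. Compound 2 `Cc1c(C(=O)N=C(N)N)ccc(Cl)c1S(C)(=O)=O` gives 1300 nM, the highest of the three numbers. Compound 3 `CS(=O)(=O)c1cc(C(=O)N=C(N)N)c(Cl)cc1Oc1cccnc1` gives 52 nM, the lowest of the three numbers.

Compound 1 and compound 3 differ in one place: (pyridin-3-yl)oxy in place of chloro on an aromatic carbon. The step was a 2.7-fold lower number from compound 1 to compound 3 (0.43 log units; beyond the scatter). For the measured compounds named here, compound 2 and compound 1 differ in more than one place, and the difference between the two cores is not broken down here; their values show only that compound 2 sits well above compound 1.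

Compound 4 `Cc1c(C(=O)N=C(N)N)ccc(Oc2cccnc2)c1S(C)(=O)=O` has not yet been measured in this assay. It differs from compound 2 in one place: (pyridin-3-yl)oxy in place of chloro on an aromatic carbon. Going by the values given here, the change is of the same kind as the one from compound 1 to compound 3, but not the same, since the aromatic carbon that carries the new group is meta to a methyl group in compound 2 and meta to a chloro group in compound 1.

Among the compounds with values here, the step from compound 2 to compound 4 is expected to be about a 2.7-fold lower number from compound 2 to compound 4 (0.43 log units; beyond the scatter), close to the earlier one, because the step of a 2.7-fold lower number from compound 1 to compound 3 (0.43 log units; beyond the scatter) is the only instance of this change that has been measured, and its carrier differs from compound 2 only in the neighbouring group. On that basis compound 4 is estimated at 480 nM in this assay, with the number expected to fall between 200 nM and 1200 nM.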

Compound 4, half-maximal inhibitory concentration: 2200 nM
Estimate against measurement, compound 4: 4.6-fold (0.66 log units) below, outside the stated range (above it).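

In this assay, putting (pyridin-3-yl)oxy in place of chloro on the core of the new pair gave a 1.7-fold higher number from compound 2 to compound 4 (0.23 log units; within the scatter), so the step seen on the other core did not reappear there. Set side by side, the two instances of this one change do not agree in size, and they are best read as two different results rather than as one transferable step: the same change on two cores in this assay, a 2.7-fold lower number (0.43 log units; beyond the scatter) from compound 1 to compound 3 and a 1.7-fold higher number (0.23 log units; within the scatter) from compound 2 to compound 4, 4.6-fold (0.66 log units) apart, beyond the scatter of two such steps. This shows that, in this series, the lower number gained on one core cannot simply be assumed on another, but it does not show which of the differences between the two cores is responsible, and two pairs give no rule for any further core.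

The compounds shown leave open whether other groups entering at the same aromatic carbon, such as a methoxy group, a phenoxy group or an amine, would also give steps that differ between these two cores. For the compounds shown here, they also leave open whether a core carrying an ethyl group or a hydrogen in place of the methyl group would follow the step seen with compound 3 or the one seen with compound 4.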